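Swapping an Amino Group for Phenyl on a Carbonyl

This account rests on a few compounds, and the source may have more. Where it says the series, first, only, none or still open, it means among the compounds named here.

Compound 1, `CC(/C=C/CC(C)CCCC(C)C)=C\C(=O)Oc1ccccc1`: 7.67
Compound 2, `CCSC(=O)/C=C(C)/C=C/CC(C)CCCC(C)C`: 7.98
Compound 3, `CC(/C=C/CC(C)CCCC(C)C)=C\C(=O)NC(C)C`: 5.65

These three compounds share a long branched chain that ends at a carbonyl carbon, and all were measured in a physicochemical assay for lipophilicity; on this read-out lower numbers stand for lower lipophilicity and higher numbers for higher lipophilicity. Compound 3 gives the lowest of the three numbers, with compound 1 nearest to it and compound 2 furthest away. Compound 4, `CC(/C=C/CC(C)CCCC(C)C)=C\C(=O)c1ccccc1`, differs from compound 3 in one place: phenyl in place of isopropylamino on a carbonyl carbon. Among the compounds with values here, two measured steps bear on this change, since both involve leaving or arriving at isopropylamino: a number 2.02 log units lower from compound 1 to compound 3 (beyond the scatter) and a number 2.33 log units lower from compound 2 to compound 3 (beyond the scatter). Read in the reverse direction, each is a large rise, so a large rise in this assay is expected here as well, bringing compound 4 close to compound 1 and compound 2. Compound 4 is estimated at 7.8, between 7.2 and 8.4, which is expected to mean a number 2.15 log units higher from compound 3 to compound 4 (beyond the scatter).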

Compound 4, partition coefficient: 7.26
Beside the measured number, compound 4's estimate is 0.54 log units above it; measured number inside the range.
By their numbers in this assay, from the lowest: compound 3; then compound 4; then compound 1; then compound 2.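

With phenyl on the carbonyl carbon, the number in this assay climbs steeply, a number 1.61 log units higher from compound 3 to compound 4 (beyond the scatter), yet it does not quite reach the level of the phenoxy or ethylsulfanyl compounds, with a number 0.41 log units lower from compound 1 to compound 4 (beyond the scatter) and a number 0.72 log units lower from compound 2 to compound 4 (beyond the scatter). Among the four groups now seen at this position, isopropylamino stands far below the other three, which are separated only by modest steps. No measurement shown explains these differences. The compounds leave open where dimethylamino, whose nitrogen carries no hydrogen, would fall in this assay. A carboxylic acid at this position also remains an open case.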